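Hydroxy substitution on the tetrahydropyridine core

A few compounds are considered here, and "the series" means these few. Any claim that something is new, unique, unknown or untested is made for them only; others in the source may bear on it.

In an assay on HEK293 cells for inhibition of diacylglycerol lipase-alpha (Homo sapiens), read by colorimetric assay, with stated times of 30 min, 60 s and 20 min (on this read-out higher numbers stand for weaker inhibition and lower numbers for stronger inhibition), compound 1 `O=C(N1CCC=C[C@@H]1COCc1ccccc1)n1cc(-c2ccc(-c3ccccc3)cc2)nn1` gives 25.1 nM, the lowest of the two numbers in hand. Its nearest neighbour is compound 2 `O=C(N1CCC=C[C@H]1COCc1ccccc1)n1cc(-c2ccc(-c3ccccc3)cc2)nn1`, which in this assay gives 1260 nM; the step of a 50-fold higher number from compound 1 to compound 2 (1.70 log units; beyond the scatter) rests on (the fact that compounds 1 and 2 differ only in the configuration as drawn), the two compounds sharing every atom and bond and differing only in the configuration drawn at the ring carbon.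

Compound 3 `O=C(N1C[C@H](O)C=C[C@@H]1COCc1ccccc1)n1cc(-c2ccc(-c3ccccc3)cc2)nn1`, not yet measured, differs from compound 1 by hydroxy in place of hydrogen on a saturated ring carbon. For the measured compounds named here, the only measured step is the configurational one from compound 1 to compound 2, and it does not bear on adding a hydroxy group: no compound in hand carries a substituent at that ring position, so no measured step speaks to the size or direction of this change. The configuration at the carbon bearing the (benzyloxy)methyl group is kept as in compound 1, the stronger epimer.

Going by the values given here, with no precedent, compound 3 is expected to stay near compound 1, the step of a 1.6-fold higher number from compound 1 to compound 3 (0.20 log units; within the scatter) being estimated as small and uncertain in direction. Compound 3 is therefore estimated at 40 nM in this assay, within 8 nM to 200 nM.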

Compound 3, half-maximal inhibitory concentration: 25.1 nM
For compound 3 the middle estimate is 1.6-fold (0.20 log units) above the measured one; measured number inside the range.
By their numbers in this assay, from the lowest: compounds 1 and 3 (each within the scatter of the next); then compound 2.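

In this assay, hydroxy in place of hydrogen on this saturated ring carbon, two ring bonds from the ring nitrogen, gives no change at the digits printed from compound 1 to compound 3 (within the scatter) and leaves the reading of the series where it stood. For the compounds shown here, this is the first evidence on this position, showing that it can carry a hydroxy group with no step beyond the scatter, whereas the earlier pair gave only a 50-fold higher number from compound 1 to compound 2 (1.70 log units; beyond the scatter) at the ring carbon bearing the (benzyloxy)methyl group. The one available fact concerns configuration at that other carbon and does not bear on the hydroxy result.

Open, from the compounds shown here alone, is whether this carbon takes other groups as readily, such as a methoxy group, an amine, a carboxylic acid or a longer chain. Also open, going by these compounds, is whether the drawn configuration of the hydroxy carbon matters as much as the configuration at the carbon bearing the (benzyloxy)methyl group, and how a hydroxy group behaves with that second carbon drawn as in compound 2.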